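The compounds below may be only part of what the source reports. "The series", "measured", "known", "first", "only" and "open" are said of these compounds alone.

Compound 1, `Nc1cccc(Cn2cc(CCCCC[C@@H]3SC[C@@H]4NC(=O)N[C@@H]43)nn2)c1`, gives > 16000 nM in an assay on isolated protein for inhibition of biotin--protein ligase (Homo sapiens), read by scintillation counting, with a stated time of 10 min; a lower number here means a stronger inhibitor, a higher number a weaker inhibitor.
Compound 2, `O=C1N[C@H]2[C@H](CS[C@H]2CCCCCc2cn(Cc3ccc(C(F)(F)F)cc3)nn2)N1`, gives > 16000 nM in this assay.

Compound 1 stands only at a limit of the assay, not at a number. Compound 2 likewise stands only at a limit of the assay. The step from compound 1 to compound 2, a step that the two limits leave unreadable from compound 1 to compound 2, is therefore not readable, since the limit of > 16000 nM in this assay, at which 2 of the 2 values shown sit, is where both values sit. Compound 3, `O=C1N[C@H]2[C@H](CS[C@H]2CCCCCc2cn(Cc3ccc(I)cc3)nn2)N1`, differs from compound 2 in that (iodo in place of trifluoromethyl on an aromatic carbon). No measured step bears on the size of this change, because the one step shown, a step that the two limits leave unreadable from compound 1 to compound 2, cannot be read. With compound 2 at a limit, compound 3 is expected to give a value in this assay of about 25000 nM, within 8000 nM to 80000 nM. The step from compound 2 to compound 3 is thus estimated as a step that the limit leaves unreadable from compound 2 to compound 3, most likely again reported only as a limit.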

Compound 3, inhibition constant: > 16000 nM
Compound 3 gave a limit, no number (the forecaster's own chance of this, stated with the estimate: 80%); the middle value is on the limit's open side.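

Compound 3 gives only a limit in this assay, not a number, so its steps from compound 1 and from compound 2 cannot be read: the limit of > 16000 nM in this assay, at which 3 of the 3 values shown sit.

The compounds shown leave open whether 3-aminophenyl, 4-(trifluoromethyl)phenyl and 4-iodophenyl differ at all in this assay.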